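This account rests on a few compounds, and the source may have more. Where it says the series, first, only, none or still open, it means among the compounds named here.

Three compounds share one core and differ only in the group that hangs from it. In a functional assay on HeLa cells (Homo sapiens) for inhibition, read by MTT assay, with a stated time of 24 h (a lower number here means a stronger inhibitor, a higher number a weaker inhibitor), compound 1 `CCOC(=O)C1=Cc2ccccc2OC1(OCc1cc(-c2ccc(OC)cc2)no1)C(F)(F)F` gives > 150000 nM, which is a limit of the assay and not a number. Compound 3 `CCOC(=O)C1=Cc2ccccc2OC1(OCc1cc(-c2ccc(C)cc2)no1)C(F)(F)F` gives > 150000 nM in this assay, again a limit. The step that the two limits leave unreadable from compound 1 to compound 3 therefore cannot be read in either size or direction. Among the compounds with values here, compound 2 `CCOC(=O)C1=Cc2ccccc2OC1(OCc1cn(-c2ccc(C)cc2)nn1)C(F)(F)F` gives 25100 nM in this assay, the only true number among the three values shown, since the two others sit at the limit of > 150000 nM in this assay, at which 2 of the 3 values shown sit.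

Compound 4 `CCOC(=O)C1=Cc2ccccc2OC1(OCc1cn(CC(=O)Nc2ccc(I)cc2Cl)nn1)C(F)(F)F` has not yet been measured. It differs from compound 2 in one place: ((2-chloro-4-iodophenyl)carbamoyl)methyl in place of 4-methylphenyl on an aromatic nitrogen. Within the data shown here, no measured step bears on this change. Among the measured compounds shown here, the single measured step, from compound 1 to compound 3, swaps one small group on an aromatic carbon for another and is unreadable, so it gives no guide to what happens when a larger group replaces the 4-methylphenyl on the aromatic nitrogen. The expectation for compound 4 must therefore rest on compound 2 alone, with a wide range around it. Compound 4 is estimated to give 30000 nM in this assay, between 6000 nM and 150000 nM. The expected step of a 1.2-fold higher number from compound 2 to compound 4 (0.08 log units; within the scatter) is within the scatter, with no direction claimed.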

Compound 4, half-maximal inhibitory concentration: 26100 nM
Compound 4: the middle estimate sits 1.1-fold (0.06 log units) above what was measured, within the range that was stated.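

In this assay, putting ((2-chloro-4-iodophenyl)carbamoyl)methyl in place of 4-methylphenyl on the aromatic nitrogen gives a 1.0-fold higher number from compound 2 to compound 4 (0.02 log units; within the scatter), so the two compounds cannot be told apart. This is the first readable step among the compounds shown, and it shows that at this position a group with an amide hydrogen, a carbonyl, a chlorine and an iodine reads the same as a plain 4-methylphenyl group, even though it carries 12 heavy atoms in place of 7. Nothing shown explains why the two groups read alike.

Compound 1 and compound 3 both stay at a limit of the assay, which is not a number, so the step between them cannot be read: the limit of > 150000 nM in this assay, at which 2 of the 4 values shown sit. With only two groups shown on this nitrogen, a single step gives no trend, and it stays open whether a plain methyl, a longer chain, an amine or a carboxylic acid there would read the same, and whether the chlorine and the iodine matter on their own.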